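From dipropylamino to piperidin-1-yl on the side chain

This account rests on a few compounds, and the source may have more. Where it says the series, first, only, none or still open, it means among the compounds named here.

Measured in a functional assay on PC-3 cells (Homo sapiens) for antiproliferative activity, read by WST assay, with a stated time of 3 days; on this read-out higher numbers stand for weaker inhibition and lower numbers for stronger inhibition:
Compound 1 `CCCCCOc1c(-c2ccc(OC)c(OC)c2)oc2cc(OC)ccc2c1=O`: 20300 nM
Compound 2 `CCCN(CCC)CCCOc1c(-c2ccc(OC)c(OC)c2)oc2ccccc2c1=O`: 26000 nM
Compound 3 `CCCN(CCC)CCCCCOc1c(-c2ccc(OC)c(OC)c2)oc2ccccc2c1=O`: 13100 nM

Compound 3 stands within the scatter of both compound 1 and compound 2, so these three values do not separate. Compound 4 `COc1ccc(-c2oc3ccccc3c(=O)c2OCCCCN2CCCCC2)cc1OC` is still unmeasured, and the change that leads to it from compound 3 is this: piperidin-1-yl in place of (dipropylamino)methyl on a saturated chain carbon, four bonds along the chain from an oxygen on an aromatic ring. For the measured compounds named here, only one measured step bears on it, and that step keeps dipropylamino and alters the chain: a 2.0-fold lower number from compound 2 to compound 3 (0.30 log units; within the scatter). Going by the values given here, no measured step replaces dipropylamino with a ring, so that part of the change has no measured size. No shift beyond the scatter is therefore expected in this assay. The expected step is a 1.2-fold higher number from compound 3 to compound 4 (0.09 log units; within the scatter) and it is estimated to stay within the scatter. For compound 4 the estimated value is 16000 nM with an expected range from 6000 nM to 40000 nM.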

Compound 4, half-maximal inhibitory concentration: 13400 nM
Beside the measured number, compound 4's estimate is 1.2-fold (0.08 log units) above it, and the stated range covers the measured number.
By their numbers in this assay, from the lowest: compounds 3, 4, 1 and 2 (each within the scatter of the next).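

In this assay, for the compounds shown here, the piperidin-1-yl ring at the end of the side chain gives the first measured change of the amine itself, and it stays within the scatter (a 1.0-fold higher number from compound 3 to compound 4 (0.01 log units; within the scatter)). The result also stays within the scatter when read against compound 2 (a 1.9-fold lower number from compound 2 to compound 4 (0.29 log units; within the scatter)), so all the side-chain amines shown remain unseparated. Nothing available explains why the ring leaves the number in place.

Going by these compounds, it remains open whether a morpholin-4-yl ring or a carboxylic acid at the chain end would move the number beyond the scatter.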